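The source may report more compounds than this note shows. Statements on the series, on what has been measured and on what is new or still open speak of the compounds shown alone.

Compound 1, `CC1=NN(c2cccc(Cl)c2)C(=O)C12C=CC(=O)C=C2c1cccc(C)c1`, gives 3740 nM in a functional assay on HCT-116 cells (Homo sapiens) for antiproliferative activity, read by CCK-8 assay, with a stated time of 72 h; on this read-out higher numbers stand for weaker inhibition and lower numbers for stronger inhibition.
Compound 2, `CC1=NN(c2ccc(Cl)cc2)C(=O)C12C=CC(=O)C=C2c1ccccc1`, reaches only the assay limit of > 100000 nM in this assay.
Compound 3, `CC1=NN(c2ccc(Cl)cc2)C(=O)C12C=CC(=O)C=C2c1ccc(C)cc1`, gives 10300 nM in this assay.

Compound 3 holds the highest of the two measured numbers, and compound 1 sits at a lower number, a gap that is beyond the scatter. Compound 4, `CC1=NN(c2cccc(Cl)c2)C(=O)C12C=CC(=O)C=C2c1ccc(C)cc1`, differs from compound 3 by 3-chlorophenyl in place of 4-chlorophenyl on an amide-type nitrogen in a ring. For the measured compounds named here, the single measured step, an at least 9.7-fold lower number from compound 2 to compound 3 (0.98 log units; beyond the scatter), concerns the methyl on the other aromatic ring and not the chlorine, and the limit for compound 2 is the limit of > 100000 nM in this assay, at which 1 of the 3 values shown sits. Going by the values given here, no measured step tells how moving the chlorine alone changes this assay, so no step beyond the scatter is expected; the lower number of compound 1, which also carries the 3-chlorophenyl, is the only hint of direction. Compound 4 is therefore expected at about 6000 nM, within 2000 nM to 20000 nM. The expected step is a 1.7-fold lower number from compound 3 to compound 4 (0.23 log units; within the scatter).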

Compound 4, half-maximal inhibitory concentration: 2400 nM
Compound 4: middle estimate off by 2.5-fold (0.40 log units), on the high side; low and high end bracket the measured number.
By their numbers in this assay, from the lowest: compounds 4 and 1 (each within the scatter of the next); then compound 3. At a limit, above all of these: compound 2.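

In this assay, for the compounds shown here, moving the chlorine alone gives a 4.3-fold lower number from compound 3 to compound 4 (0.63 log units; beyond the scatter) with the 4-methylphenyl held constant, so 3-chlorophenyl in place of 4-chlorophenyl on the amide-type nitrogen makes a difference beyond the scatter, which no earlier pair could show. With the 3-chlorophenyl kept, 4-methylphenyl in place of 3-methylphenyl on the double-bonded ring carbon gives a 1.6-fold lower number from compound 1 to compound 4 (0.19 log units; within the scatter) and so stays within the scatter, which means that moving the methyl shows no measurable change in this pair. Nothing given here explains why the position of the chlorine matters.

Going by these compounds, it remains open what an amine or a carboxylic acid in place of the chlorine would do in this assay. On these data alone, it is also open whether 3-chlorophenyl keeps its advantage over 4-chlorophenyl when the double-bonded ring carbon carries an unsubstituted phenyl.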